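The source may report more compounds than this note shows. Statements on the series, on what has been measured and on what is new or still open speak of the compounds shown alone.

Measured so far in an ADME assay on PBMC cells (Homo sapiens) for cytotoxicity; on this read-out higher numbers stand for lower toxicity in this test and lower numbers for higher toxicity in this test:
- compound 1 `CCc1c(Cc2cc(C)cc(C)c2)n(COCc2ccc(C(=O)/C=C(\O)C(=O)O)cc2)c(=O)[nH]c1=O`: > 10000 nM (a limit)
- compound 2 `O=Cc1ccc(-c2cc(-c3cccc(C=O)c3)c(O)c(O)c(=O)c2O)cc1`: 6000 nM
- compound 3 `CC(C)c1c(Cc2ccccc2)n(COCc2ccccc2)c(=O)[nH]c1=O`: > 10000 nM (a limit)

Compound 1 stands at a limit of this assay and has no exact number: compound 1 reads > 10000 nM. Compound 3 is also a limit, at > 10000 nM. Together these two make up (the limit of > 10000 nM in this assay, at which 2 of the 3 values shown sit). For the measured compounds named here, compound 2 gives 6000 nM, the only exact number so far.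

Still to be measured is compound 4 `Cc1cc(C)cc(Cc2c(C(C)C)c(=O)[nH]c(=O)n2COCc2ccc(C(=O)/C=C(\O)C(=O)O)cc2)c1`. It differs from compound 1 in one place: methyl in place of hydrogen on a saturated chain carbon bound to an aromatic carbon and a saturated chain carbon. This is methyl in place of hydrogen on a saturated chain carbon bound to an aromatic carbon and a saturated chain carbon, which also reads as ethyl to isopropyl.

Going by the values given here, no measured pair shows this change directly, so its size in this assay cannot be read from the series. No step beyond the usual scatter is expected, and no direction is favoured. This expectation rests on (the limit of > 10000 nM in this assay, at which 2 of the 3 values shown sit), which includes compound 1.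

The expected step is a step that the limit leaves unreadable from compound 1 to compound 4. Compound 4 will most likely also return a limit rather than a number. For compound 4 the estimated value is 12000 nM, with an expected range from 5000 nM to 30000 nM.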

Compound 4, half-maximal cytotoxic concentration: > 10000 nM
Compound 4: a limit, no number; the forecaster's own chance of this, stated with the estimate: 80%; the middle value lies beyond the limit too.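

In this assay compound 4 reads > 10000 nM, which is a limit and not a number. Compound 1 reads > 10000 nM, also a limit, so no step can be read between compound 1 and compound 4. The compounds shown leave open whether ethyl to isopropyl changes this read-out at all, with most values sitting at one limit: the limit of > 10000 nM in this assay, at which 3 of the 4 values shown sit.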